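Swapping a long chain for a short branched one

The source may report more compounds than this note shows. Statements on the series, on what has been measured and on what is new or still open speak of the compounds shown alone.

Compound 1 `CCC(=O)OC[C@H]1O[C@@H](O[C@@H]2OC=C(C(=O)OC)[C@H]3C[C@H](OC(C)=O)[C@H](C)[C@@H]23)[C@H](OC(C)=O)[C@@H](OC(C)=O)[C@@H]1OC(C)=O` gives 4.88 ug/mL
Compound 2 `CCCCCCCCCCCC(=O)OC[C@H]1O[C@@H](O[C@@H]2OC=C(C(=O)OC)[C@H]3C[C@H](OC(C)=O)[C@H](C)[C@@H]23)[C@H](OC(C)=O)[C@@H](OC(C)=O)[C@@H]1OC(C)=O` gives 1.24 ug/mL

In a functional assay on Caco-2 cells (Homo sapiens) for cytotoxicity, read by colony formation (on this read-out lower numbers stand for stronger inhibition and higher numbers for weaker inhibition), compound 2 stands lowest of the two, with 1.24 ug/mL as its value. Compound 3 `COC(=O)C1=CO[C@@H](O[C@@H]2O[C@H](COC(=O)C=C(C)C)[C@@H](OC(C)=O)[C@H](OC(C)=O)[C@H]2OC(C)=O)[C@@H]2[C@@H](C)[C@@H](OC(C)=O)C[C@H]12` differs from compound 2 by one group (2-methylprop-1-en-1-yl in place of undecyl on a carbonyl carbon), 2-methylprop-1-en-1-yl in place of undecyl on a carbonyl carbon. Going by the values given here, only one measured step bears on this (a 3.9-fold lower number from compound 1 to compound 2 (0.59 log units; beyond the scatter)), a modest one in which nonyl in place of hydrogen lengthened the chain. Shortening the chain should partly reverse it, although no measured compound carries this double bond. Expected is a rise of similar or slightly smaller size (a 2.8-fold higher number from compound 2 to compound 3 (0.45 log units; beyond the scatter)) in this assay for this change. For compound 3 the estimated value is 3.5 ug/mL within an expected range (1.5 ug/mL to 8 ug/mL).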

Compound 3, half-maximal inhibitory concentration: 6.2 ug/mL
The estimate for compound 3 lay 1.8-fold (0.25 log units) below the measured number; the range from low to high includes it.
By their numbers in this assay, from the lowest: compound 2; then compounds 1 and 3 (each within the scatter of the next).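

In this assay, replacing undecyl with 2-methylprop-1-en-1-yl on this carbonyl carbon gives a 5.0-fold higher number from compound 2 to compound 3 (0.70 log units; beyond the scatter), so the stronger reading of compound 2 does not survive this shortening. Against the ethyl group, the same change gives a 1.3-fold higher number from compound 1 to compound 3 (0.10 log units; within the scatter), so these two short groups cannot be told apart here, double bond or not. Nothing measured explains the difference between long and short chains. Still open, going by these compounds, is how the number moves with a mid-length chain such as hexyl, or with a chain longer than undecyl.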